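Methoxy removal on the shared core: compound 2 to compound 4

A few compounds are considered here, and "the series" means these few. Any claim that something is new, unique, unknown or untested is made for them only; others in the source may bear on it.

Working notes on the series. In a functional assay on BT-549 cells (Homo sapiens) for cytotoxicity, read by sulforhodamine B assay, with a stated time of 48 h, tested at 10 uM (on this read-out lower numbers stand for a stronger effect and higher numbers for a weaker effect at the one concentration tested), compound 1 `COc1ccc(-c2cc(/C=C/C(=O)c3ccc(N)cc3)[nH]n2)cc1` gives -37%, compound 2 `COc1cc(-c2cc(/C=C/C(=O)c3ccc(N)cc3)[nH]n2)cc(OC)c1OC` gives -89%, and compound 3 `COc1cc(-c2cc(/C=C/C(=O)c3ccc(F)c(F)c3)[nH]n2)cc(OC)c1OC` gives 23%. Compound 2 stands lowest of the three numbers; compound 1 is its nearest neighbour and compound 3 its furthest. For the measured compounds named here, the one step measured so far, a number 112 percentage points higher from compound 2 to compound 3 (beyond the scatter), concerns the group on the carbonyl carbon, not the methoxy pattern, so it does not bear directly on the change now considered.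

Compound 4 `COc1ccc(-c2cc(/C=C/C(=O)c3ccc(N)cc3)[nH]n2)cc1OC` differs from compound 2 as follows: hydrogen in place of methoxy on an aromatic carbon. Going by the values given here, no measured step follows this change on its own. Compound 1 and compound 2 differ in more than one place, so their values can only be read as showing that the compound with fewer methoxy groups gives the higher number in this assay. On that basis a moderate rise in this assay from compound 2 to compound 4 is expected, which is estimated as a number 24 percentage points higher from compound 2 to compound 4 (beyond the scatter). Compound 4 is therefore estimated at -65%, within a range from -95% to -30%.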

Compound 4, a percentage reported as activity, at one concentration (the size of the read-out at that concentration, not a potency): -91%
Compound 4: middle estimate off by 26 percentage points, on the high side; the range from low to high includes it.
By their numbers in this assay, from the lowest: compounds 4 and 2 (each within the scatter of the next); then compound 1; then compound 3.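

In this assay, hydrogen in place of methoxy on an aromatic carbon, at the site ortho to a methoxy group and meta to a large group, gives a number 2 percentage points lower from compound 2 to compound 4 (within the scatter), so on this core the methoxy group at that site makes no readable difference. The methoxy group that compound 4 carries and compound 1 lacks is another matter: methoxy in place of hydrogen on an aromatic carbon gives a number 54 percentage points lower from compound 1 to compound 4 (beyond the scatter), a large step that could not be assigned from compound 1 and compound 2 alone, as those two differ in more than one place. Nothing available bears on why one methoxy group counts in this read-out and the other does not.

Still open, on these data alone, is whether a different group at the site that tolerates hydrogen, such as a hydroxyl, a fluorine atom or an ethoxy group, would also leave the number where it stands. As far as these compounds go, it is equally open whether the same methoxy removal holds with 3,4-difluorophenyl on the carbonyl carbon, the group carried by compound 3 at 23%.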